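Swapping Bromo for Chloro on a Methylated Indole Core

This account rests on a few compounds, and the source may have more. Where it says the series, first, only, none or still open, it means among the compounds named here.

Measured so far:
- compound 1, `COC(=O)[C@@]1(C)CCC=C2[C@@H]1CC[C@@H](C)[C@]2(C)Cc1c[nH]c2c(Br)cccc12`: in a functional assay on WiDr cells (Homo sapiens) for inhibition, read by sulforhodamine B assay, with a stated time of 48 h (a higher number here means a weaker inhibitor of growth, a lower number a stronger inhibitor of growth), compound 1 gives 32000 nM
- compound 2, `COC(=O)[C@@]1(C)CCC=C2[C@@H]1CC[C@@H](C)[C@]2(C)Cc1c[nH]c2c(Cl)cccc12`: in this assay compound 2 gives 31000 nM
- compound 3, `COC(=O)[C@@]1(C)CCC=C2[C@@H]1CC[C@@H](C)[C@]2(C)Cc1c(C)[nH]c2c(Br)cccc12`: in this assay compound 3 gives 38000 nM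

Compounds 1 and 2 differ only by chloro in place of bromo on an aromatic carbon. That change gave a 1.0-fold lower number from compound 1 to compound 2 (0.01 log units; within the scatter), so the two are indistinguishable in this assay. Compound 3 shares the core of compound 1 apart from methyl in place of hydrogen on an aromatic carbon, a change that gave a 1.2-fold higher number from compound 1 to compound 3 (0.07 log units; within the scatter), again indistinguishable.

Compound 4, `COC(=O)[C@@]1(C)CCC=C2[C@@H]1CC[C@@H](C)[C@]2(C)Cc1c(C)[nH]c2c(Cl)cccc12`, has not yet been measured. It differs from compound 3 by chloro in place of bromo on an aromatic carbon, the same change as from compound 1 to compound 2, at a place described in the same words.

Because the earlier step was a 1.0-fold lower number from compound 1 to compound 2 (0.01 log units; within the scatter), the expected step from compound 3 to compound 4 is a 1.0-fold lower number from compound 3 to compound 4 (0.01 log units; within the scatter). This expectation rests on a single measured pair, so it carries the usual uncertainty of one comparison. For compound 4 the estimate in this assay is 37000 nM, expected to fall between 18000 nM and 75000 nM.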

Compound 4, concentration for 50% growth inhibition: 29000 nM
Compound 4: the middle estimate sits 1.3-fold (0.11 log units) above what was measured, within the range that was stated.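

In this assay, chloro in place of bromo behaves the same on both cores, with no difference that can be told from assay noise: the same change on two cores in this assay, a 1.0-fold lower number (0.01 log units; within the scatter) from compound 1 to compound 2 and a 1.3-fold lower number (0.12 log units; within the scatter) from compound 3 to compound 4, 1.3-fold (0.10 log units) apart, within the scatter of two such steps. Methyl in place of hydrogen on an aromatic carbon carries over in the same way: the same change on two cores in this assay, a 1.2-fold higher number (0.07 log units; within the scatter) from compound 1 to compound 3 and a 1.1-fold lower number (0.03 log units; within the scatter) from compound 2 to compound 4, 1.3-fold (0.10 log units) apart, within the scatter of two such steps. The new steps are a 1.3-fold lower number from compound 3 to compound 4 (0.12 log units; within the scatter) and a 1.1-fold lower number from compound 2 to compound 4 (0.03 log units; within the scatter) and both are small, so these four compounds show that neither change moves the number measurably on these two cores, but they do not show a real effect that travels between cores, nor whether the same would hold on a third core.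

Still open, going by these compounds, is whether a different group at the halogen's place, such as an amine or a methoxy group, would move the number beyond the scatter. The same question stands for a longer chain in place of the methyl and for a carboxylic acid in place of the ester on the shared core.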